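From acetoxy to methanesulfonamido at the assay limit

A few compounds are considered here, and "the series" means these few. Any claim that something is new, unique, unknown or untested is made for them only; others in the source may bear on it.

Measured in an ADME assay on HEK293-A cells (Homo sapiens) for cytotoxicity, read by MTT assay, with a stated time of 48 h (a higher number here means a weaker inhibitor, a lower number a stronger inhibitor), with both values limits of the assay:
compound 1 `O=C1O[C@@H](CO)CN1c1ccc(-n2cc(-c3ccccn3)cn2)c(F)c1` | > 400 ug/mL
compound 2 `CC(=O)OC[C@H]1CN(c2ccc(-n3cc(-c4ccccn4)cn3)c(F)c2)C(=O)O1` | > 400 ug/mL

Compound 2 stands at > 400 ug/mL in this assay and that is a limit of the assay, not a number. The whole picture so far is the limit of > 400 ug/mL in this assay, at which 2 of the 2 values shown sit, and nothing finer.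

Compound 3 `CS(=O)(=O)NC[C@H]1CN(c2ccc(-n3cc(-c4ccccn4)cn3)c(F)c2)C(=O)O1` has not yet been measured. It departs from compound 2 by methanesulfonamido in place of acetoxy on a saturated chain carbon bound to a saturated ring carbon and so carries methanesulfonamido in place of acetoxy on a saturated chain carbon bound to a saturated ring carbon, while the shared core stays as it is.

For the measured compounds named here, the one measured step at this part of the molecule is a step that the two limits leave unreadable from compound 1 to compound 2 and it offers no size to carry over. It put acetyl in place of hydrogen on an oxygen on a saturated carbon. With only these limits as a guide, no step beyond the usual scatter is expected in this assay and no direction can be given.

The expected step is a number no higher from compound 2 to compound 3 (the limit leaves the size open) and it remains an estimate. For compound 3 the expected value is 400 ug/mL with an estimated range of 180 ug/mL to 800 ug/mL and a good chance that the assay again reports only a limit.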

Compound 3, half-maximal inhibitory concentration: 314 ug/mL
For compound 3 the middle estimate is 1.3-fold (0.11 log units) above the measured one; the range from low to high includes it.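

In this assay, for the compounds shown here, compound 3 gives 314 ug/mL, the first value at this position that is a number and not a limit of the assay. Methanesulfonamido in place of acetoxy on a saturated chain carbon bound to a saturated ring carbon gives an at least 1.2-fold lower number from compound 2 to compound 3 (0.10 log units; that floor lies within the scatter), and the same group in place of hydroxy gives an at least 1.2-fold lower number from compound 1 to compound 3 (0.10 log units; that floor lies within the scatter); each of these is only a floor, so the true size of both steps remains open. The change thus shows that this position can bring the read-out to a measurable number, which the earlier pair could not show, as the picture otherwise remains at a single limit: the limit of > 400 ug/mL in this assay, at which 2 of the 3 values shown sit.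

The compounds shown cannot separate the part played by the sulfonyl group from that of the nitrogen, and an acetamido group on the same carbon, which would keep the acetyl and bring in the nitrogen, is not among them. Also left open is how a free amine or a longer chain at this place would read in this assay.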